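Swapping the Amide Substituent on a Benzimidazole Anilide

The source may hold more compounds than are shown below. What is called first, only, known or untested is meant among the compounds shown, and "the series" means these compounds.

Of the compounds shown here, three sharing one core have been tested in an ADME assay on NIH3T3 cells (Mus musculus) for cytotoxicity, read by resazurin assay, with a stated time of 48 h; on this read-out higher numbers stand for weaker inhibition and lower numbers for stronger inhibition. Compound 1 `O=C(Nc1cccc(-c2nc3ccccc3[nH]2)c1)c1cccs1` carries a thiophen-2-yl group on the carbonyl carbon and gives 15000 nM. Compound 2 `O=C(Nc1cccc(-c2nc3ccccc3[nH]2)c1)C1CCCCC1` carries a cyclohexyl group in the same place and gives 22200 nM. For compound 3 `Cc1cccc2[nH]c(-c3cccc(NC(=O)c4cccs4)c3)nc12` this assay reports only a limit, > 300000 nM, and not a number. The exchange of the ring on the carbonyl carbon, a 1.5-fold higher number from compound 1 to compound 2 (0.17 log units; within the scatter), therefore changes little, while the single methyl on the core, an at least 20-fold higher number from compound 1 to compound 3 (1.30 log units; beyond the scatter), moves the result far, ending at the limit of > 300000 nM in this assay, at which 1 of the 3 values shown sits. Of the two numbers, compound 2 and compound 1 sit close together, within the scatter of each other, and the third value is a limit.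

Compound 4 `O=C(Nc1cccc(-c2nc3ccccc3[nH]2)c1)c1ccc(F)cc1` has not yet been measured. It differs from compound 2 in one place: 4-fluorophenyl in place of cyclohexyl on a carbonyl carbon. Among the compounds with values here, the only measured step that bears on this is the ring exchange on the carbonyl carbon, which stayed within the scatter, so no step beyond the scatter is expected, with the estimated change being a 1.3-fold lower number from compound 2 to compound 4 (0.12 log units; within the scatter). Compound 4 is therefore expected to give about 17000 nM in this assay, between 6000 nM and 50000 nM.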

Compound 4, half-maximal inhibitory concentration: 15400 nM
Compound 4: the middle estimate sits 1.1-fold (0.04 log units) above what was measured, within the range that was stated.
By their numbers in this assay, from the lowest: compounds 1, 4 and 2 (each within the scatter of the next). At a limit, above all of these: compound 3.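

In this assay the 4-fluorophenyl group on the carbonyl carbon gives two steps, a 1.4-fold lower number from compound 2 to compound 4 (0.16 log units; within the scatter) against cyclohexyl and a 1.0-fold higher number from compound 1 to compound 4 (0.01 log units; within the scatter) against thiophen-2-yl, and neither moves the read-out beyond the scatter. Before this result, the position had been probed by a single exchange, so one flat step could have been a chance pairing of two rings. It now holds three different rings, one non-aromatic and two aromatic, and all three pairs lie within the scatter, so in these compounds a change from a non-aromatic to an aromatic ring at this position does not register in the read-out.

On these data alone, whether something other than a ring on the carbonyl carbon, such as an amine, a carboxylic acid or a longer chain, would also leave the number in place remains open, as does whether the methyl on the core would have the same large effect alongside cyclohexyl or 4-fluorophenyl. Nothing in the data shown gives a reason why these three rings read alike.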